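Swapping a cyclohexyl for a cyclopropyl on a pyrimidine amine

A few compounds are considered here, and "the series" means these few. Any claim that something is new, unique, unknown or untested is made for them only; others in the source may bear on it.

Measured so far:
Compound 1 `CCN1CCN(c2ccc(Nc3ncc4c(n3)N(C)C(=O)N(c3cc(NC(=O)c5cccc(C(F)(F)F)c5)ccc3C)C4)cn2)CC1` gives 264 nM in an ADME assay on BaF3 cells (Mus musculus) for inhibition, read by CellTiter-Glo, with a stated time of 72 h; a lower number here means a stronger inhibitor of growth, a higher number a weaker inhibitor of growth.
Compound 2 `Cc1ccc(NC(=O)c2cccc(C(F)(F)F)c2)cc1N1Cc2cnc(NCCO)nc2N(C)C1=O` gives 3290 nM in this assay.
Compound 3 `Cc1ccc(NC(=O)c2cccc(C(F)(F)F)c2)cc1N1Cc2cnc(NC3CCCCC3)nc2N(C)C1=O` gives 5220 nM in this assay.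

Compound 3 has the highest number of the three. Its nearest neighbour is compound 2, whose value sits within the scatter of it, while compound 1 lies far below it, well beyond the scatter. Within the data shown here, the one measured step that touches the same position, a 1.6-fold higher number from compound 2 to compound 3 (0.20 log units; within the scatter), shows that exchanging one group on this nitrogen for another left the number essentially where it was.

Compound 4 `Cc1ccc(NC(=O)c2cccc(C(F)(F)F)c2)cc1N1Cc2cnc(NC3CC3)nc2N(C)C1=O` differs from compound 3 in one place: cyclopropyl in place of cyclohexyl on a nitrogen on an aromatic ring. Among the measured compounds shown here, both the group that leaves and the group that enters are plain carbon rings without donors or acceptors, so the only guide is the step from compound 2 to compound 3, which stayed within the scatter. The step from compound 3 to compound 4 is therefore expected to be small, with no clear direction, as a 1.2-fold lower number from compound 3 to compound 4 (0.06 log units; within the scatter). Compound 4 is estimated at 4500 nM, with a range from 1500 nM to 13000 nM.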

Compound 4, concentration for 50% growth inhibition: 5060 nM
The estimate for compound 4 lay 1.1-fold (0.05 log units) below the measured number; measured number inside the range.
By their numbers in this assay, from the lowest: compound 1; then compounds 2, 4 and 3 (each within the scatter of the next).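

Replacing the cyclohexyl ring (6 heavy atoms) with the much smaller cyclopropyl ring (3 heavy atoms) in this assay gives a 1.0-fold lower number from compound 3 to compound 4 (0.01 log units; within the scatter), so these two plain carbon rings on the nitrogen cannot be told apart by this read-out. The comparison with a chain ending in a hydroxyl group gives a 1.5-fold higher number from compound 2 to compound 4 (0.19 log units; within the scatter), which means that compound 2, compound 3 and compound 4 all remain within the scatter of one another despite their different groups. Nothing available explains why these changes leave the number in place.

From the compounds shown here alone, it remains open whether a plain phenyl ring on this nitrogen would approach compound 1 at 264 nM or stay with the other three. A basic amine on a short chain at this nitrogen is equally untested here.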